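This account rests on a few compounds, and the source may have more. Where it says the series, first, only, none or still open, it means among the compounds named here.

Measured compounds in an assay on isolated protein with dual specificity calcium/calmodulin-dependent 3',5'-cyclic nucleotide phosphodiesterase 1B (Bos taurus) as the target, tested at 100 uM; on this read-out lower numbers stand for less inhibition and higher numbers for more inhibition at the one concentration tested (going by the name of the read-out):
compound 1 `Nc1nc2c(c(=O)n(CC3CC3)c(=O)n2CC2CC2)n1S(=O)(=O)c1ccccc1`: 13%
compound 2 `Cc1ccc(S(=O)(=O)n2c(N)nc3c2c(=O)n(CC2CC2)c(=O)n3CC2CC2)cc1`: 9%
compound 3 `COc1ccc(S(=O)(=O)n2c(N)nc3c2c(=O)n(CC2CC2)c(=O)n3CC2CC2)cc1`: 25%

Compound 3 gives the highest of the three numbers; its nearest neighbour is compound 1, beyond the scatter, and compound 2 lies furthest, also beyond the scatter. The step to compound 4 `COc1ccc(OC)c(S(=O)(=O)n2c(N)nc3c2c(=O)n(CC2CC2)c(=O)n3CC2CC2)c1` is 2,5-dimethoxyphenyl in place of 4-methoxyphenyl on a sulfonyl sulfur. Within the data shown here, no measured pair carries exactly this change. Among the measured compounds shown here, the steps that bear on it are the two in which a methoxy entered on an aromatic carbon: a number 12 percentage points higher from compound 1 to compound 3 (beyond the scatter) and a number 16 percentage points higher from compound 2 to compound 3 (beyond the scatter), both modest rises beyond the scatter. The step of a number 4 percentage points lower from compound 1 to compound 2 (within the scatter) shows that a methyl on an aromatic carbon changed nothing beyond the scatter. Compound 4 keeps a methoxy-bearing ring while a second methoxy enters, so a further small rise, or no change beyond the scatter, is expected in this assay. Compound 4 is estimated at 28%, between 10% and 48%. That estimate means an expected step of a number 3 percentage points higher from compound 3 to compound 4 (within the scatter).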

Compound 4, a percentage reported as inhibition, at one concentration (the size of the read-out at that concentration, not a potency): 31%
Compound 4: middle estimate off by 3 percentage points, on the low side; the measured number falls inside the stated range.
By their numbers in this assay, from the lowest: compounds 2 and 1 (each within the scatter of the next); then compounds 3 and 4 (each within the scatter of the next).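

Working notes on the sulfonyl sulfur position in this assay: the exchange of 4-methoxyphenyl for 2,5-dimethoxyphenyl gives a number 6 percentage points higher from compound 3 to compound 4 (within the scatter), so compound 3 and compound 4 cannot be told apart and the second methoxy brings no readable gain. The 2,5-dimethoxyphenyl group does separate from the rings without methoxy, with a number 22 percentage points higher from compound 2 to compound 4 (beyond the scatter) and a number 18 percentage points higher from compound 1 to compound 4 (beyond the scatter), which places both methoxy-bearing compounds in one band above the phenyl and 4-methylphenyl compounds among these four, with none going against it. No supporting measurement is available to explain this grouping.

Among these compounds, whether a methoxy is the only group that gives this separation stays open, since an amine or a carboxylic acid on the same ring could read differently. Going by these compounds, with one concentration per compound, the potency of the series also remains open.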